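Carboxy added to the benzoxazole: half-life in cynomolgus monkey

This account rests on a few compounds, and the source may have more. Where it says the series, first, only, none or still open, it means among the compounds named here.

Compound 2 `CCCCN(c1nc2ccccc2o1)[C@H](C)c1ccc(-c2ccccc2-c2nnn[nH]2)cc1`: 3.2 h
Compound 1 `C[C@H](c1ccc(-c2cc(Cl)ccc2-c2nc(=O)o[nH]2)cc1)N(CC1CC1)c1nc2c(C(=O)O)cccc2o1`: 0.8 h

In an ADME assay on the whole organism (Macaca fascicularis) for metabolic stability, read by LC-MS, using cassette dosing, at a dose of 1 mg/kg by the oral route (on this read-out higher numbers stand for a longer-lived compound and lower numbers for a shorter-lived compound), compound 2 gives 3.2 h, the higher of the two numbers measured; compound 1 gives 0.8 h, and that gap lies beyond the scatter, though the two compounds differ in several places at once. Compound 3 `CCCCN(c1nc2c(C(=O)O)cccc2o1)[C@H](C)c1ccc(-c2ccccc2-c2nnn[nH]2)cc1` carries the change carboxy in place of hydrogen on an aromatic carbon relative to compound 2 and is not yet measured. For the measured compounds named here, compound 1, the only measured compound bearing a carboxy, is the shorter-lived one. A moderate fall is therefore expected for compound 3, a 1.8-fold lower number from compound 2 to compound 3 (0.25 log units; within the scatter), with compound 3 estimated at 1.8 h, between 0.8 h and 4 h.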

Compound 3, half-life: 3.7 h
Estimate against measurement, compound 3: 2.1-fold (0.31 log units) below; the measured number falls inside the stated range.
By their numbers in this assay, from the lowest: compound 1; then compounds 2 and 3 (each within the scatter of the next).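

In this assay, the change from 1,3-benzoxazol-2-yl to 4-carboxy-1,3-benzoxazol-2-yl gives a 1.2-fold higher number from compound 2 to compound 3 (0.06 log units; within the scatter), so with the butyl chain and tetrazole in place, carboxy at this position leaves the half-life unmoved. The short half-life of compound 1 therefore cannot be laid on the carboxy alone. No measurement at hand offers an explanation for this result.

On these data alone, whether an amine or a methyl ester at this position would read the same stays open. So does which of the other features of compound 1, such as its chlorine or cyclopropylmethyl group, goes with its 0.8 h.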